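The source may hold more compounds than are shown below. What is called first, only, known or untested is meant among the compounds shown, and "the series" means these compounds.

Compound 1 `O=c1c(O)c(-c2ccccc2)oc2cc(OCc3ccccc3Cl)cc(O)c12` is the starting point. In an ADME assay on Huh-5-2 cells (Homo sapiens) for cytotoxicity, read by WST assay, with a stated time of 3 days (a higher number here means that more compound is tolerated, a lower number that less compound is tolerated), compound 1 reaches only the limit of the assay, > 100000 nM, so no number is known for it, and where it stands can be said only as a limit. Among the measured compounds shown here, its one measured neighbour is compound 2 `COc1ccccc1COc1cc(O)c2c(=O)c(O)c(-c3ccccc3)oc2c1`, which differs in a single place: methoxy in place of chloro on an aromatic carbon. In this assay compound 2 likewise sits at a limit, > 100000 nM. The step that the two limits leave unreadable from compound 1 to compound 2 is therefore unreadable; the two values reveal nothing about its size or direction, because the limit of > 100000 nM in this assay, at which 2 of the 2 values shown sit, holds for every value shown.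

Compound 3 `O=c1c(O)c(-c2ccccc2)oc2cc(OCc3cccc(Br)c3)cc(O)c12` differs from compound 1 at the same benzylic position: 3-bromophenyl in place of 2-chlorophenyl on a saturated chain carbon bound to an oxygen on an aromatic ring. For the measured compounds named here, the only measured step that bears on this change is the unreadable one, so there is no basis for expecting a shift beyond the scatter in this assay in either direction. Compound 3 is expected to stay at the limit as well, with an estimated step that the limit leaves unreadable from compound 1 to compound 3. Compound 3 is thus estimated at 150000 nM, with a range from 50000 nM to 500000 nM.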

Compound 3, half-maximal cytotoxic concentration: > 100000 nM
Compound 3: only a limit was reported; the forecaster's own chance of this, stated with the estimate: 80%; the middle value is on the limit's open side.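

Compound 3 gives > 100000 nM in this assay, which is a limit and not a number. No step among compound 1, compound 2 and compound 3 can be read, and the reason lies in a shared ceiling: the limit of > 100000 nM in this assay, at which 3 of the 3 values shown sit.

The compounds shown leave open how far any of these benzyl changes shifts tolerance, and in which direction.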